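Swapping the aryl substituents on an amide in dopamine receptor agonists

The compounds below may be only part of what the source reports. "The series", "measured", "known", "first", "only" and "open" are said of these compounds alone.

Three compounds share a core in which a piperidine carries an aryl group and is linked through an acetamide to a substituted phenyl ring. Compound 1 `O=C(CN1CCC(c2cccc[n+]2[O-])CC1)Nc1cccc(Cl)c1` gives 62 nM in a functional assay on HEK293 cells for agonist activity at D(4) dopamine receptor (Homo sapiens), read by FLIPR; a lower number here means that less compound is needed, a higher number that more compound is needed for the effect. Compound 2 `Cc1cccc(NC(=O)CN2CCC(c3ccccc3C#N)CC2)c1` gives 8 nM. Compound 3 `Cc1cc(C)cc(NC(=O)CN2CCC(c3cccc[n+]3[O-])CC2)c1` gives 52 nM and stands second highest of the three numbers, nearest to compound 1 and furthest from compound 2. For the measured compounds named here, the one single-point step among the measured compounds, a 1.2-fold lower number from compound 1 to compound 3 (0.08 log units; within the scatter), changes only the substituents on the phenyl attached to the amide nitrogen and stays within the scatter.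

Compound 4 `Cc1cc(NC(=O)CN2CCC(c3cccc[n+]3[O-])CC2)ccc1F` has not yet been measured. It differs from compound 3 in one place: 4-fluoro-3-methylphenyl in place of 3,5-dimethylphenyl on an amide-type nitrogen. This is again a swap of substituents on the phenyl that sits on the amide nitrogen, the same kind of change as the step from compound 1 to compound 3, which stayed within the scatter. Going by the values given here, no other measured pair bears on it. The expectation for this assay is therefore a step of a 1.0-fold lower number from compound 3 to compound 4 (0.02 log units; within the scatter), that is, no change beyond the scatter. Compound 4 is estimated at 50 nM, within a range from 20 nM to 130 nM.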

Compound 4, half-maximal effective concentration: 18 nM
Compound 4: the middle estimate sits 2.8-fold (0.44 log units) above what was measured; the whole stated range lies above it.
By their numbers in this assay, from the lowest: compound 2; then compound 4; then compounds 3 and 1 (each within the scatter of the next).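

The earlier swap on this phenyl stayed within the scatter, but this one shows that the group on the amide-type nitrogen can shift the number in this assay: there is a 2.9-fold lower number from compound 3 to compound 4 (0.46 log units; beyond the scatter), and the comparison with the chlorinated compound gives a 3.4-fold lower number from compound 1 to compound 4 (0.54 log units; beyond the scatter). The counts computed for the two groups do not separate them, as 3,5-dimethylphenyl and 4-fluoro-3-methylphenyl have the same number of heavy atoms and neither has a hydrogen-bond donor or acceptor, so the step goes with replacing one carbon-bearing group's atoms by a set that includes fluorine. Nothing measured here gives a reason for the lower number.

The compounds shown leave open whether fluorine itself matters, since a chlorine or a methoxy group in its place on the same ring would be needed to test this. They also leave open whether 4-fluoro-3-methylphenyl would give a similar step when the other end of the molecule carries the nitrile-bearing ring of compound 2 instead of the ring shared by compound 1, compound 3 and compound 4.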